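Amino-chain variation on a diarylurea piperazine series

This account rests on a few compounds, and the source may have more. Where it says the series, first, only, none or still open, it means among the compounds named here.

Measured so far in an assay on CHO cells for binding affinity to Substance-P receptor (Homo sapiens); a higher number here means a weaker inhibitor, a lower number a stronger inhibitor:
- compound 1 `CCCCCN(CCCCC)C(=O)N1CCN(C(=O)N(c2ccccc2)c2ccccc2)[C@H](C(=O)NCC(=O)O)C1`: 597 nM
- compound 2 `CCCCCN(CCCCC)C(=O)N1CCN(C(=O)N(c2ccccc2)c2ccccc2)[C@H](C(=O)NCCN(C)C)C1`: 55 nM
- compound 3 `CCCCCN(CCCCC)C(=O)N1CCN(C(=O)N(c2ccccc2)c2ccccc2)[C@H](C(=O)NCCN(CC)CC)C1`: 11 nM

Compound 3 stands lowest of the three numbers in this assay. Its nearest neighbour is compound 2, reached by a 5.0-fold lower number from compound 2 to compound 3 (0.70 log units; beyond the scatter); the furthest is compound 1, reached by a 54-fold lower number from compound 1 to compound 3 (1.73 log units; beyond the scatter). The step of an 11-fold lower number from compound 1 to compound 2 (1.04 log units; beyond the scatter) shows the same direction. Both moves away from the carboxy terminus lowered the number, and the larger amino group lowered it further.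

Compound 4 `CCCCCN(CCCCC)C(=O)N1CCN(C(=O)N(c2ccccc2)c2ccccc2)[C@H](C(=O)NCCNCc2ccccc2OC)C1` differs from compound 3 by (2-methoxybenzyl)amino in place of diethylamino on a saturated chain carbon, two bonds along the chain from an amide-type nitrogen. The steps from compound 1 to compound 3 and from compound 2 to compound 3 bear on it only loosely: they show that a basic terminus is favoured over carboxy and that a larger one was better than a smaller one, but none of them swaps a tertiary amine for a secondary one carrying a ring. Among the compounds with values here, no measured step covers that exchange directly. The expectation is therefore a step of a 1.1-fold lower number from compound 3 to compound 4 (0.04 log units; within the scatter), within the scatter, in either direction. Compound 4 is expected at 10 nM, with a range of 3 nM to 40 nM.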

Compound 4, half-maximal inhibitory concentration: 9 nM
The estimate for compound 4 lay 1.1-fold (0.05 log units) above the measured number; low and high end bracket the measured number.
By their numbers in this assay, from the lowest: compounds 4 and 3 (each within the scatter of the next); then compound 2; then compound 1.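

In this assay, the position two bonds along the chain from the amide-type nitrogen takes (2-methoxybenzyl)amino, with its aromatic ring and hydrogen-bond donor, in place of diethylamino without separation from compound 3: a 1.2-fold lower number from compound 3 to compound 4 (0.09 log units; within the scatter). The size of the terminal group therefore does not track the number in the way the dimethylamino to diethylamino step alone suggested, although the separation from the smaller amine and from the acid holds: a 6.1-fold lower number from compound 2 to compound 4 (0.79 log units; beyond the scatter), and a 66-fold lower number from compound 1 to compound 4 (1.82 log units; beyond the scatter). No supporting evidence is available to explain why the two different termini give matching numbers.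

From the compounds shown here alone, whether the methoxy group contributes at all remains open, and a plain benzylamino terminus would address this. Also open, going by these compounds, is how a longer chain between the amide nitrogen and the amine would read.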